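From Cyanomethoxy to Benzylamino: Cytotoxicity Expected to Stay Unreadable

The source may hold more compounds than are shown below. What is called first, only, known or untested is meant among the compounds shown, and "the series" means these compounds.

Compound 1 `CCC1(Cc2ccccc2)OS(=O)(=O)C=C1OCC#N` was tested in an ADME assay on HEL cells (Homo sapiens) for cytotoxicity, with a stated time of 3 days; a lower number here means that less compound is tolerated, a higher number that more compound is tolerated. In this assay compound 1 gives > 200000 nM, which is a limit of the assay rather than a number. Compound 2 `CCC1(Cc2ccccc2)OS(=O)(=O)C=C1OCc1ccc(Cl)cc1` gives > 200000 nM, likewise a limit. Among the compounds with values here, the only measured step, a step that the two limits leave unreadable from compound 1 to compound 2, therefore cannot be read, since both values sit at the limit of > 200000 nM in this assay, at which 2 of the 2 values shown sit. Compound 3 `CCC1(Cc2ccccc2)OS(=O)(=O)C=C1NCc1ccccc1` differs from compound 1 by benzylamino in place of cyanomethoxy on a double-bonded ring carbon, a benzylamino in place of cyanomethoxy on a double-bonded ring carbon. Within the data shown here, no measured step speaks to this change, so no shift beyond the scatter is expected. Compound 3 is estimated at 250000 nM, between 60000 nM and 1000000 nM, an expected step that the limit leaves unreadable from compound 1 to compound 3.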

Compound 3, half-maximal cytotoxic concentration: 92000 nM
Compound 3: middle estimate off by 2.7-fold (0.43 log units), on the high side; measured number inside the range.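

In this assay, within the data shown here, this position is the first place where a change can be read: benzylamino in place of cyanomethoxy on the double-bonded ring carbon gives an at least 2.1-fold lower number from compound 1 to compound 3 (0.33 log units; beyond the scatter). Less of compound 3 is therefore tolerated, and it is the only compound shown with a real number. As far as these compounds go, the true size of the step stays unknown, as its starting point is only a limit: the limit of > 200000 nM in this assay, at which 2 of the 3 values shown sit.

From the compounds shown here alone, what remains open is whether the ring-bearing benzyl part or the nitrogen link matters more. A plain amino group or a benzyloxy group at this position would separate the two.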